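Swapping a Phenol for a Methoxy Group on the Imine

A few compounds are considered here, and "the series" means these few. Any claim that something is new, unique, unknown or untested is made for them only; others in the source may bear on it.

Compound 1 `CCCCCCCCCCCCCCNC(=O)[C@H](CO)/N=C/c1ccc(O)cc1` joins a long saturated chain through an amide to a shared core whose nitrogen forms a double bond to a carbon bearing a 4-hydroxyphenyl ring. Going by the values given here, in a functional assay on cells (Homo sapiens) for cytotoxicity, read by MTT assay, with a stated time of 24 h (on this read-out lower numbers stand for stronger inhibition and higher numbers for weaker inhibition), compound 1 gives 19300 nM, the second highest of the three numbers known so far. Compound 2 `CCCCCCCCCCCCCCNC(=O)[C@H](CO)/N=C/c1ccccc1` gives 7670 nM, and compound 3 `CCCCCCCCCCCCCCNC(=O)[C@H](CO)NCc1ccccc1Cl` gives 43700 nM. Compound 4 `CCCCCCCCCCCCCCNC(=O)[C@H](CO)/N=C/c1cccc(OC)c1` differs from compound 1 in one place: 3-methoxyphenyl in place of 4-hydroxyphenyl on a carbon with a double bond to nitrogen. The step bearing most directly on this change is a 2.5-fold lower number from compound 1 to compound 2 (0.40 log units; beyond the scatter), in which the hydroxy alone was removed. The step of a 2.3-fold higher number from compound 1 to compound 3 (0.35 log units; beyond the scatter) also touches this region but alters the link to the nitrogen as well, so it guides less. Compound 4 likewise lacks the hydrogen-bond donor, so a modest drop in number is expected for compound 4, in line with a 2.5-fold lower number from compound 1 to compound 2 (0.40 log units; beyond the scatter), with extra uncertainty from the methoxy. Compound 4 is therefore estimated at 9000 nM, within 3000 nM to 30000 nM. This estimate means an expected step of a 2.1-fold lower number from compound 1 to compound 4 (0.33 log units; beyond the scatter).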

Compound 4, half-maximal inhibitory concentration: 31300 nM
Compound 4: the middle estimate sits 3.5-fold (0.54 log units) below what was measured; measured number above the stated range.
By their numbers in this assay, from the lowest: compound 2; then compounds 1, 4 and 3 (each within the scatter of the next, the first and the last beyond it).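

In this assay, exchanging 4-hydroxyphenyl for 3-methoxyphenyl on a carbon with a double bond to nitrogen gives a 1.6-fold higher number from compound 1 to compound 4 (0.21 log units; within the scatter), so this change leaves the two compounds indistinguishable. Adding methoxy to the plain phenyl ring gives a 4.1-fold higher number from compound 2 to compound 4 (0.61 log units; beyond the scatter), which shows that lacking the ring hydroxy is not enough on its own to keep the number as low as that of compound 2. The comparison with the chlorine-bearing compound gives a 1.4-fold lower number from compound 3 to compound 4 (0.14 log units; within the scatter), so the methoxy imine also cannot be separated from it in this assay.

From the compounds shown here alone, it remains open whether an amine or a carboxylic acid on the ring would give a number close to that of compound 2 or close to those of compound 1 and compound 4. Nothing shown here gives a measured reason for the gap between the plain phenyl and the 3-methoxyphenyl compounds.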